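The source may report more compounds than this note shows. Statements on the series, on what has been measured and on what is new or still open speak of the compounds shown alone.

Measured compounds:
compound 1 `C#CCOc1ccc(/C=C/C(C)=O)cc1OC` gives 49700 nM in a functional assay on HCT-116 cells (Homo sapiens) for antiproliferative activity, read by MTT assay, with a stated time of 48 h; a lower number here means a stronger inhibitor, a higher number a weaker inhibitor
compound 2 `COc1cccc(-n2cc(COc3ccc(/C=C/C(C)=O)cc3OC)nn2)c1` gives 29600 nM in this assay

Only these two numbers exist so far. Going by the values given here, compound 2 gives the lower of the two, but the gap to compound 1 lies within the usual scatter of repeated runs, so the pair does not establish an order; both sit in the weak range of this assay and no step between them has been worked out.

Compound 3 `COc1cc(/C=C/C(C)=O)ccc1OCc1cn(-c2ccc(C=O)cc2)nn1` has not been measured. It differs from compound 2 in one place: 4-formylphenyl in place of 3-methoxyphenyl on an aromatic nitrogen. The shared core, the enone chain and the ring-linked ether are kept, and the exchange touches only the ring hanging from the ring nitrogen.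

Among the compounds with values here, nothing among the measured compounds shows what a swap of this kind does in this assay. The expectation is therefore a step of a 1.1-fold lower number from compound 2 to compound 3 (0.02 log units; within the scatter) of no real size, in either direction, and not beyond the scatter. Compound 3 is estimated at 28000 nM in this assay, with a range from 9000 nM to 85000 nM.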

Compound 3, half-maximal inhibitory concentration: 76200 nM
Compound 3: middle estimate off by 2.7-fold (0.43 log units), on the low side; measured number inside the range.
By their numbers in this assay, from the lowest: compounds 2, 1 and 3 (each within the scatter of the next, the first and the last beyond it).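

In this assay, going by these compounds alone, the ring on the aromatic nitrogen is the first place where an exchange gives a step that can be read: 4-formylphenyl in place of 3-methoxyphenyl gives a 2.6-fold higher number from compound 2 to compound 3 (0.41 log units; beyond the scatter) and thus a weaker compound. This position therefore responds to what its ring carries, although the step is modest and rests on this single pair. The entering and leaving groups have the same counts of heavy atoms and hydrogen-bond acceptors, so those counts do not separate the two compounds, and no measurement at hand bears on the reason for the step.

The group and its location on the ring change together in this exchange, so the pair leaves open whether the step follows the formyl group, its location, or the removal of the methoxy group. Also open, from the compounds shown here alone, is how this ring would behave with no added group, as plain phenyl, or with a carboxylic acid, a hydroxymethyl group or an aminomethyl group in place of the formyl group.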